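Trimethoxyphenyl Replacing Methoxyphenyl on a Benzophenone Nucleoside Ester

The source may report more compounds than this note shows. Statements on the series, on what has been measured and on what is new or still open speak of the compounds shown alone.

Measured compounds:
- compound 1, `COc1cccc(C(=O)c2ccc(OC)c(OC(=O)CCC(=O)OC[C@@H]3C=C[C@H](n4cc(C)c(=O)[nH]c4=O)O3)c2)c1`: 770 nM
- compound 2, `COc1ccc(C(=O)c2ccc([N+](=O)[O-])cc2)cc1OCC(=O)OC[C@@H]1C=C[C@H](n2cc(C)c(=O)[nH]c2=O)O1`: 48100 nM

Both compounds were tested in a functional assay on SGC-7901 cells (Homo sapiens) for antiproliferative activity, read by MTT assay, with a stated time of 48 h; a lower number here means a stronger inhibitor, a higher number a weaker inhibitor. For the measured compounds named here, compound 1 gives the lowest of the two numbers; compound 2, the only other measured compound, sits far away from it, and the two differ in more than one place, so nothing about a single change can be read from that pair.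

Compound 3, `COc1cc(OC)c(C(=O)c2ccc(OC)c(OC(=O)CCC(=O)OC[C@@H]3C=C[C@H](n4cc(C)c(=O)[nH]c4=O)O3)c2)cc1OC`, has not yet been measured. It differs from compound 1 in one place: 2,4,5-trimethoxyphenyl in place of 3-methoxyphenyl on a carbonyl carbon. No comparable single-point change has been measured here, so the size of the step is uncertain. A moderate step is expected in this assay, probably toward a weaker inhibitor, though a result within the scatter is also possible. The expected step from compound 1 is a 1.9-fold higher number from compound 1 to compound 3 (0.29 log units; within the scatter). For compound 3 the estimated value is 1500 nM, within a range of 300 nM to 8000 nM.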

Compound 3, half-maximal inhibitory concentration: 2270 nM
Estimate against measurement, compound 3: 1.5-fold (0.18 log units) below; measured number inside the range.
By their numbers in this assay, from the lowest: compound 1; then compound 3; then compound 2.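

In this assay, putting 2,4,5-trimethoxyphenyl in place of 3-methoxyphenyl on a carbonyl carbon gives a 2.9-fold higher number from compound 1 to compound 3 (0.47 log units; beyond the scatter), with the rest of the molecule unchanged. For the compounds shown here, this is the first comparison here that isolates one change, and it shows that the group on this carbonyl carbon affects the read-out: the larger group, with two more methoxy groups, gives a weaker inhibitor, although the step is modest. Nothing measured here explains why the number rises.

A single step cannot show whether the added methoxy groups themselves matter, or where they sit on the aromatic ring. It also leaves open how this position would respond to a group of another kind, such as a phenyl ring carrying a hydroxyl group or an amine.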